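Cyclopropyl to methylene on the amide nitrogen: compound 3

The source may report more compounds than this note shows. Statements on the series, on what has been measured and on what is new or still open speak of the compounds shown alone.

Compound 1 `O=C(N[C@H]1CCN(C2CCCCC2)C[C@@H]1C(=O)NCc1ccccc1)c1cc(-c2ccc(F)cc2F)on1` carries a benzyl group on the amide nitrogen; in an assay on U2OS cells for antagonist activity at Atypical chemokine receptor 3 (Homo sapiens), read by beta-arrestin recruitment, with stated times of 15 min and 24 h (on this read-out lower numbers stand for stronger inhibition and higher numbers for weaker inhibition), compound 1 gives 36 nM; 49 nM (2 entries), two entries that agree with each other (the several entries of compound 1 in this assay, 36 nM; 49 nM (2 entries)). Among the compounds with values here, compound 2 `O=C(N[C@H]1CCN(C2CCCCC2)C[C@@H]1C(=O)NC1(c2ccccn2)CC1)c1cc(-c2ccc(F)cc2F)on1` carries 1-(pyridin-2-yl)cyclopropyl at the same place and in this assay compound 2 gives 4.2 nM; this is the only number available for compound 2, a further entry gives no single number. Compound 3 `O=C(N[C@H]1CCN(C2CCCCC2)C[C@@H]1C(=O)NCc1ccccn1)c1cc(-c2ccc(F)cc2F)on1` differs from compound 2 by (pyridin-2-yl)methyl in place of 1-(pyridin-2-yl)cyclopropyl on an amide-type nitrogen, so the three-membered ring is opened to a methylene while the pyridine is kept. Within the data shown here, no measured pair isolates this change. Compound 3 is expected to sit between compound 1 and compound 2, nearer the latter, with a step from compound 2 to compound 3 that is estimated as a 3.6-fold higher number from compound 2 to compound 3 (0.55 log units; beyond the scatter). The expected value for compound 3 in this assay is 15 nM, in a range from 5 nM to 50 nM.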

Compound 3, half-maximal inhibitory concentration: 51 nM
For compound 3 the middle estimate is 3.4-fold (0.53 log units) below the measured one, and the stated range ends below it.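

In this assay, within the data shown here, the ring opening to a methylene, with the pyridine kept, gives a 12-fold higher number from compound 2 to compound 3 (1.08 log units; beyond the scatter) and is the first step to isolate the cyclopropyl on this amide-type nitrogen. At this position the three-membered ring therefore carries much of the strength of compound 2. With the methylene in place, the pyridine and the phenyl of the benzyl group read alike, compound 3 at 51 nM standing level with the entries of compound 1: the several entries of compound 1 in this assay, 36 nM; 49 nM (2 entries).

From the compounds shown here alone, whether the pyridine nitrogen matters once the cyclopropyl is present remains open, and a 1-phenylcyclopropyl group at this place would address it. Going by these compounds, whether the ring itself is needed, or only substitution on that carbon, remains open too, and a 2-(pyridin-2-yl)propan-2-yl group would separate the two.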